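This account rests on a few compounds, and the source may have more. Where it says the series, first, only, none or still open, it means among the compounds named here.

The measured compounds are:
compound 1, `Cc1ccc(CN(C)C(=O)c2nn(-c3ccc(F)cc3)c(OC[C@@H](O)C[C@@H](O)CC(=O)O)c2C(C)C)cc1`, giving 37 nM in an assay on microsomes from liver for inhibition of 3-hydroxy-3-methylglutaryl-coenzyme A reductase (Rattus norvegicus); on this read-out higher numbers stand for weaker inhibition and lower numbers for stronger inhibition;
compound 2, `COc1cc(CN(C)C(=O)c2nn(-c3ccc(F)cc3)c(OC[C@@H](O)C[C@@H](O)CC(=O)O)c2C(C)C)cc(OC)c1`, giving 43 nM in this assay;
compound 3, `CC(C)c1c(C(=O)N(C)Cc2cccc(Cl)c2)nn(-c2ccc(F)cc2)c1OC[C@@H](O)C[C@@H](O)CC(=O)O`, giving 8.3 nM in this assay.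

All three share one core and differ only in the aromatic ring attached through a saturated chain carbon to the amide nitrogen. Compound 3 shows the lowest number of the three: the step of a 4.5-fold lower number from compound 1 to compound 3 (0.65 log units; beyond the scatter) and the step of a 5.2-fold lower number from compound 2 to compound 3 (0.71 log units; beyond the scatter) are both beyond the scatter, while the step of a 1.2-fold higher number from compound 1 to compound 2 (0.07 log units; within the scatter) is not. Compound 4, `CC(C)c1c(C(=O)N(C)Cc2cccc(C(F)(F)F)c2)nn(-c2ccc(F)cc2)c1OC[C@@H](O)C[C@@H](O)CC(=O)O`, keeps the core of compound 3 and changes that ring in one place: trifluoromethyl in place of chloro on an aromatic carbon. Among the measured compounds shown here, no measured pair tests this exact exchange, so the two steps that end at compound 3 are the only guide; they show that a change on this ring can move the number by a modest amount, and they give no direction for replacing one halogen-type substituent with another at the same spot. A step within the scatter is therefore expected, a 1.2-fold higher number from compound 3 to compound 4 (0.08 log units; within the scatter), with no clear direction. Compound 4 is expected to give about 10 nM in this assay, within a range from 4 nM to 25 nM.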

Compound 4, half-maximal inhibitory concentration: 31 nM
Compound 4: the middle estimate sits 3.1-fold (0.49 log units) below what was measured, and the stated range ends below it.
By their numbers in this assay, from the lowest: compound 3; then compounds 4, 1 and 2 (each within the scatter of the next).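

In this assay, trifluoromethyl is not an interchangeable stand-in for chloro at this place on the ring (a 3.7-fold higher number from compound 3 to compound 4 (0.57 log units; beyond the scatter)), even though neither group carries a hydrogen-bond donor or acceptor. The exchange also leaves compound 4 level with the two compounds that have no chloro (a 1.4-fold lower number from compound 2 to compound 4 (0.14 log units; within the scatter); a 1.2-fold lower number from compound 1 to compound 4 (0.08 log units; within the scatter)), so among these four, only the 3-chlorobenzyl group of compound 3 stands apart from the rest. Nothing in the data at hand explains why the chloro and trifluoromethyl compounds differ.

From the compounds shown here alone, with chloro as the only halogen tried directly on this ring, it remains open whether the lower number of compound 3 is particular to chloro or would also appear with bromo, fluoro or a nitrile at the same place. Going by these compounds, it is also open whether the difference between the chloro and trifluoromethyl groups would survive if the methyl on the amide nitrogen gave way to a hydrogen or an ethyl group.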